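This account rests on a few compounds, and the source may have more. Where it says the series, first, only, none or still open, it means among the compounds named here.

Measured so far in a functional assay on WI-38 VA13 cells (Homo sapiens) for cytotoxicity; on this read-out lower numbers stand for an effect already at smaller amounts and higher numbers for an effect only at larger amounts of compound:
- compound 1 `CCCC(=O)Nc1nc2ccc(NC(=O)c3c(Cl)cccc3Cl)cc2s1` gives 0.01 ug/mL
- compound 2 `CC(C)OC(=O)Nc1nc2ccc(NC(=O)c3c(Cl)cccc3Cl)cc2s1` gives 0.0026 ug/mL

Among the compounds with values here, compound 2 has the lowest number of the two; the only other compound is compound 1, and the step of a 3.8-fold lower number from compound 1 to compound 2 (0.59 log units; beyond the scatter) lies beyond the scatter. Compound 3 `O=C(Nc1nc2ccc(NC(=O)c3c(Cl)cccc3Cl)cc2s1)Oc1ccccc1` keeps the shared core and the carbamate of compound 2, with one change: phenyl in place of isopropyl on an oxygen next to a carbonyl group. Within the data shown here, the single measured step, from compound 1 to compound 2, concerns the same carbonyl but swaps a propyl for an isopropoxy, so it says little about replacing isopropyl with phenyl on the oxygen. Among the measured compounds shown here, no measured pair shows a phenyl entering at this place. With so little to go on, the expectation is a small step, if any, in this assay, likely within the scatter: the estimate for compound 3 is 0.004 ug/mL (range 0.001 ug/mL to 0.015 ug/mL). This means an expected step of a 1.5-fold higher number from compound 2 to compound 3 (0.19 log units; within the scatter).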

Compound 3, half-maximal effective concentration: 1.1 ug/mL
Beside the measured number, compound 3's estimate is 280-fold (2.44 log units) below it, and the stated range ends below it.
By their numbers in this assay, from the lowest: compound 2; then compound 1; then compound 3.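

In this assay, the group on the carbamate oxygen turns out to matter far more than the earlier pair could show: phenyl in place of isopropyl gives a 420-fold higher number from compound 2 to compound 3 (2.63 log units; beyond the scatter) and stands as a large step. Carrying a carbamate is therefore not enough to keep the number low, since compound 2 and compound 3 both have one. Phenoxy in place of propyl on the carbonyl carbon also gives a 110-fold higher number from compound 1 to compound 3 (2.04 log units; beyond the scatter) and places compound 3 highest of the three, though nothing shown explains the jump.

As far as these compounds go, whether the ring itself or simply the larger group drives this stays open. A cyclohexyl or a benzyl group on the same oxygen could help separate those two readings, as could a smaller ethyl group.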